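This account rests on a few compounds, and the source may have more. Where it says the series, first, only, none or still open, it means among the compounds named here.

Measured compounds:
- compound 1, `O=C(Cn1nnc(-c2ccccc2)n1)Nc1cc(C2(C(F)(F)F)CC2)nn1C1CCCCC1`: "not active" (no number reported) in an assay on HEK293 cells for activation of Kir3.1/Kir3.2 (Homo sapiens), read by thallium flux; on this read-out higher numbers stand for an effect only at larger amounts of compound and lower numbers for an effect already at smaller amounts
- compound 2, `Cc1cc(NC(=O)Cn2nnc(-c3cccnc3)n2)n(C2CCCCC2)n1`: 1930 nM

Among the measured compounds shown here, compound 2 holds the only number reported in this assay; compound 1 gives no number at all, only the report of no activity, so compound 2 cannot be ranked against anything. Compound 3, `Cc1cc(NC(=O)Cn2nnc(-c3cccc(Cl)c3)n2)n(C2CCCCC2)n1`, keeps the core of compound 2 and differs in one place: 3-chlorophenyl in place of pyridin-3-yl on an aromatic carbon. For the measured compounds named here, no measured pair shows this exchange, so its size is not known from the data. Compound 1 carries a phenyl on the same ring but also a different group on the core, so it does not tell what the exchange alone does. The step from compound 2 to compound 3 in this assay is expected to be small, in the direction of a lower number, at a 1.9-fold lower number from compound 2 to compound 3 (0.29 log units; within the scatter). For compound 3 in this assay the estimate is 1000 nM, with a range from 300 nM to 3500 nM.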

Compound 3, half-maximal effective concentration: 300 nM
Compound 3: the middle estimate sits 3.3-fold (0.52 log units) above what was measured; measured number inside the range.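

Replacing pyridin-3-yl with 3-chlorophenyl on the aromatic carbon of the five-membered ring, with the rest of the molecule held constant, gives in this assay a 6.4-fold lower number from compound 2 to compound 3 (0.81 log units; beyond the scatter), the first single-place change shown here, and it demonstrates that the number responds to the group at this position. The exchange alters two things at once, since the ring nitrogen leaves and a chlorine enters, and this pair cannot separate them. Nothing measured here accounts for the step.

A plain phenyl at this position on the core of compound 2 would be needed to tell the part played by the ring nitrogen from that of the chlorine. As far as these compounds go, whether a fluorine or a methoxy group could take the place of that chlorine also remains open.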